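The source may hold more compounds than are shown below. What is called first, only, known or untested is meant among the compounds shown, and "the series" means these compounds.

Measured so far:
- compound 1 `CCN(c1cccc(-c2ccccc2)c1)c1ccc(C#N)c(Cl)c1`: "not determined" (no result reported) in a functional assay on PC-3 cells (Homo sapiens) for antiproliferative activity, read by CCK-8 assay, with a stated time of 6 days; a higher number here means a weaker inhibitor, a lower number a stronger inhibitor
- compound 2 `N#Cc1ccc(N2CCCc3c(-c4cccnc4)cccc32)cc1C(F)(F)F`: 7970 nM
- compound 3 `CCN(c1ccc(C#N)c(Cl)c1)c1cc(-c2ccnn2C)ccc1C`: 7290 nM

Compound 3 carries the lower of the two numbers, but compound 2 lies within the scatter of it, so the two are not separated by this assay. Compound 1 contributes no number. Compound 4 `CCN(c1ccc(C#N)c(Cl)c1)c1cc(-c2ccoc2)ccc1C` is not yet measured; it differs from compound 3 in one place: furan-3-yl in place of 1-methyl-1H-pyrazol-5-yl on an aromatic carbon. Among the measured compounds shown here, no step between measured compounds is available to calibrate this exchange. For the measured compounds named here, with only two similar weak values at hand, no step beyond the scatter is expected in either direction, and the expected step of a 1.1-fold higher number from compound 3 to compound 4 (0.04 log units; within the scatter) is set near zero. Compound 4 is therefore estimated at 8000 nM, with a range from 3000 nM to 20000 nM.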

Compound 4, half-maximal inhibitory concentration: > 30000 nM
Compound 4: a limit, no number; the forecaster's own chance of this, stated with the estimate: 20%; middle value at least 3.7-fold (0.57 log units) away from the limit.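

In this assay, this position on the shared core does not treat all five-membered aromatic rings alike: furan-3-yl in place of 1-methyl-1H-pyrazol-5-yl gives an at least 4.1-fold higher number from compound 3 to compound 4 (0.61 log units; beyond the scatter). That step is bounded on one side only, and the entry for compound 4 is a limit of the assay, not a number: the limit of > 30000 nM in this assay, at which 1 of the 4 values shown sits.

Going by these compounds, it remains open whether the change tracks the methyl group, the second ring nitrogen or the ring as a whole. On these data alone, how an amine or a carboxylic acid would read at this position also remains open.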